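The compounds below may be only part of what the source reports. "The series", "measured", "known", "first", "only" and "open" are said of these compounds alone.

Measured in a functional assay for antagonist activity, with Cavia porcellus as the target; on this read-out higher numbers stand for weaker inhibition and lower numbers for stronger inhibition:
- Compound 1 `CN(CC#CCCC1(C(O)(c2ccccc2)c2ccccc2)SCCCS1)Cc1ccccc1`: 3170 nM
- Compound 2 `CN(CC#CCCC1(C(O)(c2ccccc2)c2ccccc2)SCCCS1)CCCc1ccccc1`: 1630 nM
- Compound 3 `CN(C)CC#CCCC1(C(O)(c2ccccc2)c2ccccc2)SCCCS1`: 1810 nM

Compound 3 cannot be separated from the other two compounds: a 1.1-fold higher number from compound 2 to compound 3 (0.05 log units; within the scatter) and a 1.8-fold lower number from compound 1 to compound 3 (0.24 log units; within the scatter). The remaining pair is no different, with a 1.9-fold lower number from compound 1 to compound 2 (0.29 log units; within the scatter).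

Compound 4 `CCN(CC)CC#CCCCC1(C(O)(c2ccccc2)c2ccccc2)SCCCS1` is the next entry, and it carries 4-(diethylamino)but-2-yn-1-yl in place of 3-(dimethylamino)prop-1-yn-1-yl on a saturated chain carbon, two bonds along the chain from a saturated ring carbon. The three measured steps bear on this only in part. All of them concern what the amine nitrogen carries, and none goes beyond the scatter in this assay. For the measured compounds named here, no measured step covers the replacement of 3-(dimethylamino)prop-1-yn-1-yl by 4-(diethylamino)but-2-yn-1-yl as a whole, so the data leave that part of the change untested. No shift beyond the scatter is therefore expected, though with a wide margin.

The expected change is a 1.1-fold higher number from compound 3 to compound 4 (0.04 log units; within the scatter).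

For compound 4 the estimated value is 2000 nM, with an expected range of 700 nM to 5500 nM.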

Compound 4, antagonist equilibrium constant: 810 nM
Beside the measured number, compound 4's estimate is 2.5-fold (0.39 log units) above it, within the range that was stated.
By their numbers in this assay, from the lowest: compounds 4, 2, 3 and 1 (each within the scatter of the next, the first and the last beyond it).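

In this assay, for the compounds shown here, 4-(diethylamino)but-2-yn-1-yl in place of 3-(dimethylamino)prop-1-yn-1-yl gives a 2.2-fold lower number from compound 3 to compound 4 (0.35 log units; beyond the scatter), a modest shift toward stronger inhibition and the only step beyond the scatter. The earlier steps shown here changed only what the amine nitrogen carries and separated no compounds, whereas this change on a saturated chain carbon, two bonds along the chain from a saturated ring carbon, alters both the chain and the amine and does separate a pair. No evidence at hand accounts for the shift.

The compounds shown do not separate the contribution of the longer chain from that of the two ethyl groups on nitrogen, so the longer chain with dimethylamino and the shorter chain with diethylamino remain the open comparisons. Also open, as far as these compounds go, is whether a cyclic amine such as piperidine at this nitrogen would follow compound 4.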